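The source may report more compounds than this note shows. Statements on the series, on what has been measured and on what is new or still open speak of the compounds shown alone.

Compound 1 `COc1cc(C(=O)c2cn(-c3ccc(C)cc3)cc2-c2ccccc2F)cc(OC)c1OC`: 44 nM
Compound 2 `COc1cc(C(=O)c2cn(-c3ccc(C)cc3)cc2-c2ccccc2Cl)cc(OC)c1OC`: 180 nM
Compound 3 `COc1cc(C(=O)c2cn(-c3ccc(C)cc3)cc2-c2ccccc2[N+](=O)[O-])cc(OC)c1OC`: 65 nM

These values come from a functional assay on MCF7 cells (Homo sapiens) for cytotoxicity, read by MTT assay, with a stated time of 96 h; a lower number here means a stronger inhibitor, a higher number a weaker inhibitor. On these numbers, compound 3 sits within the scatter of its nearest neighbour, a 1.5-fold higher number from compound 1 to compound 3 (0.17 log units; within the scatter), but is clearly separated from its furthest, a 2.8-fold lower number from compound 2 to compound 3 (0.44 log units; beyond the scatter).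

Compound 4 `COc1cc(C(=O)c2cn(-c3ccc(C)cc3)cc2-c2ccc(N)cc2)cc(OC)c1OC` carries 4-aminophenyl in place of 2-nitrophenyl on an aromatic carbon. Among the measured compounds shown here, the only steps that bear on this are swaps of one group, and the largest, a 4.1-fold higher number from compound 1 to compound 2 (0.61 log units; beyond the scatter), is modest. None of them involves an amino group, so no firm direction can be expected in this assay, and a step of modest size at most seems likely. The estimated step is a 1.5-fold higher number from compound 3 to compound 4 (0.19 log units; within the scatter). For compound 4 the estimated value is 100 nM, with an expected range of 25 nM to 500 nM.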

Compound 4, half-maximal inhibitory concentration: 6 nM
For compound 4 the middle estimate is 17-fold (1.22 log units) above the measured one, outside the stated range (below it).
By their numbers in this assay, from the lowest: compound 4; then compounds 1 and 3 (each within the scatter of the next); then compound 2.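

In this assay, this position proved far more responsive than the swaps among fluoro, chloro and nitro had shown: 4-aminophenyl gives an 11-fold lower number from compound 3 to compound 4 (1.03 log units; beyond the scatter), together with a 7.3-fold lower number from compound 1 to compound 4 (0.87 log units; beyond the scatter) and a 30-fold lower number from compound 2 to compound 4 (1.48 log units; beyond the scatter). All three steps lie beyond the scatter, making compound 4 the most potent of the four. Nothing available here accounts for this gain.

The compounds shown do not separate the amino group from its place on the phenyl ring, a question that 2-aminophenyl and 4-fluorophenyl would address. On these data alone, whether 4-dimethylaminophenyl or 4-acetamidophenyl would keep this potency also remains open.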